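Sulfonamide for amide on the aryl acetylene series

A few compounds are considered here, and "the series" means these few. Any claim that something is new, unique, unknown or untested is made for them only; others in the source may bear on it.

Three compounds have numbers in an assay on CHO cells for displacement of a labelled ligand from prostaglandin D2 receptor 2 (Homo sapiens), read by scintillation counting; a higher number here means a weaker inhibitor, a lower number a stronger inhibitor:
compound 1, `CN(C)C(=O)c1cccc(C#Cc2cc(Cl)ccc2OCC(=O)O)c1`, 52 nM
compound 2, `CCCc1ccncc1C#Cc1cc(Cl)ccc1OCC(=O)O`, 4.3 nM
compound 3, `CS(=O)(=O)c1ccc(C#Cc2cc(Cl)ccc2OCC(=O)O)cc1`, 86 nM

Compound 1 stands second highest of the three. Its nearest neighbour is compound 3, whose number lies within the scatter of that of compound 1, so no order between the two can be read. Compound 2 gives a number far below, and that gap lies beyond the scatter.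

The next compound, compound 4, `CN(C)S(=O)(=O)c1cccc(C#Cc2cc(Cl)ccc2OCC(=O)O)c1`, keeps the shared core and changes one place: dimethylsulfamoyl in place of dimethylcarbamoyl on an aromatic carbon, meta to a large group. Among the measured compounds shown here, no pair among the measured compounds covers this exchange, so its size is unknown. The only indirect bearing is that compound 3, which also carries a sulfonyl-type group on its aryl ring, sits within the scatter of compound 1. The step expected here is a 1.2-fold higher number from compound 1 to compound 4 (0.06 log units; within the scatter), which is to say none beyond the scatter, in either direction. Compound 4 is therefore estimated at 60 nM, with a range from 25 nM to 150 nM.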

Compound 4, inhibition constant: 14 nM
Compound 4: middle estimate off by 4.3-fold (0.63 log units), on the high side, outside the stated range (below it).
By their numbers in this assay, from the lowest: compound 2; then compound 4; then compounds 1 and 3 (each within the scatter of the next).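

In this assay, dimethylsulfamoyl in place of dimethylcarbamoyl on an aromatic carbon, meta to a large group, gives a 3.7-fold lower number from compound 1 to compound 4 (0.57 log units; beyond the scatter). Among the compounds shown here, this is the first step that can be read from a pair differing in one place, and it shows that this position responds to the exchange: the step is modest in size but beyond the scatter, and it rests on this single pair. The dimethylamino part is common to both groups, so the step belongs to the replacement of the carbonyl by the sulfonyl at this one place, though nothing measured here accounts for the change in the number.

Still open, going by these compounds, is whether the step holds when the two methyl groups on the sulfonamide nitrogen give way to other substituents, as in the unsubstituted sulfonamide or a pyrrolidine sulfonamide. Also open, on these data alone, is whether the same exchange gives a step of similar size at another ring carbon, or on a core carrying a bromine in place of the chlorine.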